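Halogen swap on the fused core: cytotoxicity notes

A few compounds are considered here, and "the series" means these few. Any claim that something is new, unique, unknown or untested is made for them only; others in the source may bear on it.

Compound 3 `Cc1c(Oc2ccc(F)cc2OCCn2ccc(=O)[nH]c2=O)cc(F)c2ccc(C#N)cc12` sits at the limit of a toxicity assay on MT2 cells (Homo sapiens) for cytotoxicity, read by MTT assay; on this read-out higher numbers stand for lower toxicity in this test and lower numbers for higher toxicity in this test: in this read-out compound 3 gives > 100000 nM, which is a limit of the assay and not a number. Compound 1 `Cc1c(Oc2ccccc2OCCn2ccc(=O)[nH]c2=O)cc(Cl)c2ccc(C#N)cc12` likewise gives > 100000 nM, again a limit. Compound 2 `N#Cc1ccc2c(Cl)cc(Oc3ccc(F)cc3OCCn3ccc(=O)[nH]c3=O)cc2c1` gives > 100000 nM, also a limit. Among the measured compounds shown here, all three values shown therefore sit at the limit of > 100000 nM in this assay, at which 3 of the 3 values shown sit, so no step between measured compounds can be sized, and compound 3 stands level with the other two as far as the numbers go.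

Compound 4 `Cc1c(Oc2ccc(F)cc2OCCn2ccc(=O)[nH]c2=O)cc(Cl)c2ccc(C#N)cc12` is not yet measured; it differs from compound 3 by chloro in place of fluoro on an aromatic carbon. Compound 1 and compound 2 each already carry chloro on their cores and each sits at the limit, so nothing in the set separates chloro from fluoro on this read-out. The step of a number no higher from compound 3 to compound 4 (the limit leaves the size open) is expected to be none beyond the scatter. For compound 4 the estimate in this assay is 100000 nM, with an expected range from 50000 nM to 300000 nM, most likely reported once more as a limit.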

Compound 4, half-maximal cytotoxic concentration: 82000 nM
Compound 4: the middle estimate sits 1.2-fold (0.09 log units) above what was measured; the measured number falls inside the stated range.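

In this assay, chloro in place of fluoro on this aromatic carbon, para to a methyl group, gives an at least 1.2-fold lower number from compound 3 to compound 4 (0.08 log units; that floor lies within the scatter). Two further single changes read the same way: methyl in place of hydrogen on an aromatic carbon gives an at least 1.2-fold lower number from compound 2 to compound 4 (0.08 log units; that floor lies within the scatter), and fluoro in place of hydrogen on an aromatic carbon gives an at least 1.2-fold lower number from compound 1 to compound 4 (0.08 log units; that floor lies within the scatter). These floors show no change beyond the scatter, and the full size of each step stays open because the other three values are limits: the limit of > 100000 nM in this assay, at which 3 of the 4 values shown sit.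

On these data alone, whether bromo or an amine on this aromatic carbon would shift the number beyond the scatter remains open. Also open, as far as these compounds go, is whether the chloro and fluoro pair would read the same on a core without the methyl group.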